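The compounds below may be only part of what the source reports. "The series", "measured", "known", "first", "only" and "open" are said of these compounds alone.

Measured in a functional assay on cells (Lymphocyte), read by a luciferase reporter and ATP content, with a stated time of 48 h, tested at 25 uM; on this read-out lower numbers stand for a stronger effect and higher numbers for a weaker effect at the one concentration tested:
compound 1 `CCCCCCCCCCCCCCCCc1c(C)c(N(C)C)nc(C)c1O`, activity 37%
compound 2 `CCCCCCCCCCCCCCCCCCCc1c(C)c(N(C)C)nc(C)c1O`, activity 86%
compound 3 `CCCCCCCCCCCCCCCCCCCc1nc(N(C)C)c(C)c(C)c1O`, activity 99%

Compound 2 and compound 1 share one core and differ in a single place, (hydrogen in place of propyl on a saturated chain carbon, ten or more bonds along the chain from an aromatic carbon). In this assay this change gave a number 49 percentage points lower from compound 2 to compound 1 (beyond the scatter). Compound 3 is built from the same atoms as compound 2 joined differently; the difference between the two cores is not broken down here. Compound 3 stands highest of the three in this assay, with its steps to compound 2 and to compound 1 both beyond the scatter.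

Compound 4 `CCCCCCCCCCCCCCCCc1nc(N(C)C)c(C)c(C)c1O` has not yet been measured. It differs from compound 3 by hydrogen in place of propyl on a saturated chain carbon, ten or more bonds along the chain from an aromatic carbon, the same change as from compound 2 to compound 1, at a place described in the same words. Among the measured compounds shown here, because a number 49 percentage points lower from compound 2 to compound 1 (beyond the scatter) was a large step on the core of compound 2, a step of comparable size is expected on the core of compound 3 in this assay, namely a number 44 percentage points lower from compound 3 to compound 4 (beyond the scatter), though with only one earlier example the carry-over to a different core is uncertain and the range is kept wide. Compound 4 is therefore expected to give about 55%, estimated between 30% and 85%.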

Compound 4, a percentage reported as activity, at one concentration (the size of the read-out at that concentration, not a potency): 41%
For compound 4 the middle estimate is 14 percentage points above the measured one, within the range that was stated.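

In this assay the change from propyl to hydrogen gave a number 58 percentage points lower from compound 3 to compound 4 (beyond the scatter) and so repeated the large step seen earlier, with no difference in size beyond the scatter: the same change on two cores in this assay, a number 49 percentage points lower (beyond the scatter) from compound 2 to compound 1 and a number 58 percentage points lower (beyond the scatter) from compound 3 to compound 4, 9 percentage points apart, within the scatter of two such steps. On these two cores, then, the change carries over, and the number on the read-out falls by a similar large step on each. Among the compounds shown here, this rests on only two pairs tested at one concentration, so it does not show that the step would hold on a third core or at other chain lengths, and it gives no potency for any of the compounds.

The compounds shown leave open how the read-out would run with a shorter chain, a longer chain, or a chain carrying an amine or a carboxylic acid. Also open, going by these compounds, is whether the same step would appear with a methyl ether in place of the hydroxyl group.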